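The source may report more compounds than this note shows. Statements on the series, on what has been measured and on what is new or still open speak of the compounds shown alone.

Compound 1 `COc1cc2c(cc1OC)CN(CCn1cc(COc3ccc4ccccc4c3)nn1)CC2`: > 100000 nM, a limit.
Compound 2 `COc1cc2c(cc1OC)CN(CCn1cc(COc3cccc4ccccc34)nn1)CC2`: > 100000 nM, a limit.
Compound 3 `COc1cc2c(cc1OC)CN(CCn1cc(COc3ccc(C)cc3)nn1)CC2`: > 100000 nM, a limit.

All three results come from an ADME assay on K562/A02 cells (Homo sapiens) for cytotoxicity, read by MTT assay, with a stated time of 48 h (on this read-out lower numbers stand for stronger inhibition and higher numbers for weaker inhibition), and none is an exact number. Compound 3 therefore stands only as a limit, and the whole set rests at the limit of > 100000 nM in this assay, at which 3 of the 3 values shown sit.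

Compound 4 `COc1cc2c(cc1OC)CN(CCn1cc(COc3ccc(F)cc3)nn1)CC2` has fluoro in place of methyl on an aromatic carbon, para to a large group: fluoro in place of methyl on an aromatic carbon.

The measured steps that bear on this change alter the group on the same oxygen: a step that the two limits leave unreadable from compound 1 to compound 2, a step that the two limits leave unreadable from compound 1 to compound 3 and a step that the two limits leave unreadable from compound 2 to compound 3. None of them has a readable size, and none shows any gain in inhibition. The expected change is therefore none beyond the scatter, and a number no higher from compound 3 to compound 4 (the limit leaves the size open) is the step expected. Another limit is the most likely report. For compound 4 the estimate is 100000 nM, with an expected range of 40000 nM to 250000 nM.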

Compound 4, half-maximal inhibitory concentration: > 100000 nM
Compound 4: only a limit was reported; the forecaster's own chance of this, stated with the estimate: 85%; the middle value sits exactly at the limit.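

In this assay compound 4 gives > 100000 nM, a limit. The steps to it from compound 1, compound 2 and compound 3 therefore cannot be read. The compounds shown leave open how these four would rank in this assay, and whether any group on that oxygen changes inhibition at all.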